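Swapping tert-butyl for hydroxy: what compound 4 may give

The source may hold more compounds than are shown below. What is called first, only, known or untested is meant among the compounds shown, and "the series" means these compounds.

Measured compounds:
compound 1 `O=C(N/N=C/c1ccc(O)cc1)c1ccc(O)cc1` gives 38% in a physicochemical assay, read by spectrophotometry, with a stated time of 60 min, tested at 100 uM; on this read-out lower numbers stand for a weaker effect and higher numbers for a stronger effect at the one concentration tested
compound 2 `CC(C)(C)c1ccc(C(=O)N/N=C/c2ccc(O)cc2)cc1` gives 15% in this assay
compound 3 `CC(C)(C)c1ccc(C(=O)N/N=C/c2cc(O)cc(O)c2)cc1` gives 10.9% in this assay

Compound 1 stands highest of the three, its steps to compound 2 and to compound 3 both beyond the scatter, while compound 2 and compound 3 lie within the scatter of each other. Compound 4 `O=C(N/N=C/c1cc(O)cc(O)c1)c1ccc(O)cc1` is compound 3 with hydroxy in place of tert-butyl on an aromatic carbon. The same change is made from compound 2 to compound 1, (hydroxy in place of tert-butyl on an aromatic carbon), and there it gave a number 23 percentage points higher from compound 2 to compound 1 (beyond the scatter). How the core of compound 3 differs from the core of compound 2 is not broken down here. A step of similar size is expected for compound 4, namely a number 20.1 percentage points higher from compound 3 to compound 4 (beyond the scatter), because of a number 23 percentage points higher from compound 2 to compound 1 (beyond the scatter). Compound 4 is therefore estimated at 31%, most likely between 18% and 44%.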

Compound 4, a percentage reported as inhibition, at one concentration (the size of the read-out at that concentration, not a potency): 11.2%
Compound 4: the middle estimate sits 19.8 percentage points above what was measured, outside the stated range (below it).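

In this assay the swap of tert-butyl for hydroxy gave a number 0.3 percentage points higher from compound 3 to compound 4 (within the scatter) while on the other core the same swap gave a number 23 percentage points higher from compound 2 to compound 1 (beyond the scatter) so the change did not carry over from the core of compound 2 to the core of compound 3. This shows that, across these two pairs, the outcome of the swap depended on the core it was made on, though two pairs cannot establish a rule for the series. It does not show why the two cores differ, and nothing measured here bears on the reason.

The compounds shown leave open whether an amine, a carboxylic acid or a longer chain in place of tert-butyl would follow hydroxy on either core. They also leave open how the swap would behave on any further core.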